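A few compounds are considered here, and "the series" means these few. Any claim that something is new, unique, unknown or untested is made for them only; others in the source may bear on it.

The compounds measured so far, in a functional assay on K562 cells (Homo sapiens) for inhibition, read by fluorescence, with a stated time of 72 h; a lower number here means a stronger inhibitor of growth, a higher number a weaker inhibitor of growth:

- Compound 1 `CCCCCc1cc2nn(-c3ccccc3)cc2cn1`: 2100 nM
- Compound 2 `OCCc1cc2nn(-c3ccccc3)cc2cn1`: reaches only the limit of this assay, > 100000 nM
- Compound 3 `c1ccc(-n2cc3cnccc3n2)cc1`: reaches only the limit of this assay, > 100000 nM

Compound 3 therefore stands at the weak end of what has been measured; its number is a limit, not a value, and it shares that limit with compound 2 (the limit of > 100000 nM in this assay, at which 2 of the 3 values shown sit). The change now in question is cyclopropyl in place of hydrogen on an aromatic carbon, which gives compound 4 `c1ccc(-n2cc3cnc(C4CC4)cc3n2)cc1`. Among the measured compounds shown here, two measured steps bear on it, both running the other way. Removing the pentyl chain from the same carbon gave an at least 47-fold higher number from compound 1 to compound 3 (1.67 log units; beyond the scatter), and swapping the chain's propyl end for a hydroxy group gave an at least 47-fold higher number from compound 1 to compound 2 (1.67 log units; beyond the scatter). A saturated carbon group on that carbon thus goes with a much lower number, and its loss or its polar replacement with a number beyond the limit. Cyclopropyl is a small carbon-only ring, so a step downward from compound 3, though smaller than the pentyl step, is expected: an at least 3.3-fold lower number from compound 3 to compound 4 (0.52 log units; beyond the scatter). For compound 4 the expected value is 30000 nM, within 6000 nM to 150000 nM.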

Compound 4, concentration for 50% growth inhibition: 60500 nM
The estimate for compound 4 lay 2.0-fold (0.30 log units) below the measured number; measured number inside the range.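

Cyclopropyl on this aromatic carbon gives a number that can be read in this assay, the only one among the compounds shown apart from compound 1, so the pentyl chain is not the only group here that leaves measurable inhibition of growth. How much cyclopropyl adds is less clear: replacing hydrogen gives an at least 1.6-fold lower number from compound 3 to compound 4 (0.21 log units; that floor lies within the scatter), and replacing 2-hydroxyethyl gives an at least 1.6-fold lower number from compound 2 to compound 4 (0.21 log units; that floor lies within the scatter), and each of these is only a floor that does not by itself clear the usual scatter. Pentyl remains far ahead, since the change to cyclopropyl gives a 29-fold higher number from compound 1 to compound 4 (1.46 log units; beyond the scatter), so a carbon-only group on this carbon does not alone match compound 1.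

The compounds shown leave open whether a butyl chain or a cyclohexyl ring here would come closer to compound 1, and whether a chain longer than pentyl would lower the number further. They also leave open whether an amine at the end of the chain would fare as poorly as the hydroxy group of compound 2.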